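The compounds below may be only part of what the source reports. "The series", "measured", "known", "first", "only" and "open" are said of these compounds alone.

In a functional assay on HCT-116 cells (Homo sapiens) for inhibition, read by MTT assay, with a stated time of 48 h (on this read-out lower numbers stand for stronger inhibition and higher numbers for weaker inhibition), the measured compounds are: compound 1 `Brc1cccc(CSc2nnc(-c3ccncc3)n2-c2ccccc2)c1` with 8170 nM; compound 2 `c1ccc(CSc2nnc(-c3ccncc3)n2-c2ccccc2)cc1` with 16900 nM; compound 3 `O=C(CSc1nnc(-c2ccncc2)n1-c1ccccc1)N/N=C/c1cc(Br)ccc1O` with 1990 nM.

Compound 3 has the lowest number of the three, and its gaps to compound 1 and compound 2 are both beyond the scatter. How the core of compound 3 differs from the core of compound 1 is not broken down here. Compound 2 differs from compound 1 by hydrogen in place of bromo on an aromatic carbon, and that change gave a 2.1-fold higher number from compound 1 to compound 2 (0.32 log units; beyond the scatter).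

Compound 4 `O=C(CSc1nnc(-c2ccncc2)n1-c1ccccc1)N/N=C/c1ccccc1O` is not yet measured and differs from compound 3 by hydrogen in place of bromo on an aromatic carbon. The place is not identical: in compound 4 it is also para to a hydroxy group, so this is the same kind of change, not the same. Resting on a 2.1-fold higher number from compound 1 to compound 2 (0.32 log units; beyond the scatter), compound 4 is expected to give a 2.1-fold higher number from compound 3 to compound 4 (0.32 log units; beyond the scatter) in this assay. Compound 4 is therefore estimated at 4200 nM, between 1600 nM and 11000 nM.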

Compound 4, half-maximal inhibitory concentration: 7060 nM
Compound 4: the middle estimate sits 1.7-fold (0.23 log units) below what was measured; low and high end bracket the measured number.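

In this assay, replacing bromo with hydrogen, here as 5-bromo-2-hydroxyphenyl to 2-hydroxyphenyl, gave a 3.5-fold higher number from compound 3 to compound 4 (0.55 log units; beyond the scatter). Set beside the earlier step, the change carries across the two cores in direction and, within the scatter, in size: the same change on two cores in this assay, a 2.1-fold higher number (0.32 log units; beyond the scatter) from compound 1 to compound 2 and a 3.5-fold higher number (0.55 log units; beyond the scatter) from compound 3 to compound 4, 1.7-fold (0.23 log units) apart, within the scatter of two such steps

Going by these compounds alone, this rests on only two pairs, so it does not show that the step would hold on any further core, and it says nothing about why the number moves. The compounds shown leave open how chloro, methoxy or an amine would read in the place of bromo. Within the data shown here, they also leave open what the hydroxy group of compound 3 contributes, since no compound here carries bromo without it on that ring.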